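Swapping formyl for hydroxymethyl in compound 2

This account rests on a few compounds, and the source may have more. Where it says the series, first, only, none or still open, it means among the compounds named here.

Compound 1 `COc1ccc(/C=C/[C@@](C)(/C=C/c2ccc(O)cc2)CCC=C(C)C)cc1`: 6%
Compound 2 `COc1ccc(/C=C/[C@@](C)(/C=C/c2ccc(O)cc2)CCC=C(C)C)cc1C=O`: 35%
Compound 3 `CC(C)=CCCC(C)(/C=C/c1ccc(O)cc1)/C=C/c1ccc(O)cc1`: 30%

In a functional assay on IMR-32 cells (Homo sapiens) for inhibition, with a stated time of 48 h, tested at 50 uM (on this read-out lower numbers stand for less inhibition of growth and higher numbers for more inhibition of growth at the one concentration tested), compound 2 at 35% sits within the scatter of compound 3 at 30%, and both lie clearly clear of compound 1. Compound 4 `COc1ccc(/C=C/[C@@](C)(/C=C/c2ccc(O)cc2)CCC=C(C)C)cc1CO` differs from compound 2 in one place: hydroxymethyl in place of formyl on an aromatic carbon. The most relevant measurement is a number 29 percentage points higher from compound 1 to compound 2 (beyond the scatter), made at that same carbon. The other, a number 24 percentage points higher from compound 1 to compound 3 (beyond the scatter), concerns a different place and says little here. Among the measured compounds shown here, no measured step swaps these two groups, so a partial loss of the formyl gain is only a cautious guess. The expected change is a number 13 percentage points lower from compound 2 to compound 4 (beyond the scatter), a modest fall. Compound 4 is estimated at 22%, with an expected range of 6% to 42%.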

Compound 4, percent growth inhibition at one concentration: 34%
For compound 4 the middle estimate is 12 percentage points below the measured one; measured number inside the range.
By their numbers in this assay, from the lowest: compound 1; then compounds 3, 4 and 2 (each within the scatter of the next).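

In this assay, the step from formyl to hydroxymethyl on this aromatic carbon gives a number 1 percentage points lower from compound 2 to compound 4 (within the scatter), so the carbonyl of formyl is not required for the effect seen here. The gain over the unsubstituted carbon also appears with hydroxymethyl, which gives a number 28 percentage points higher from compound 1 to compound 4 (beyond the scatter), and the hydrogen-bond donor that hydroxymethyl brings leaves the number within the scatter of formyl. No measurement available here explains why the two groups read alike.

Going by these compounds, whether a carboxylic acid, an aminomethyl group or a longer chain on this carbon would keep the gain remains open. So does whether hydroxymethyl would add to the gain seen in compound 3.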